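This account rests on a few compounds, and the source may have more. Where it says the series, first, only, none or still open, it means among the compounds named here.

Within the data shown here, compound 2, `C[C@H](NC(=O)c1c(Cc2cc(F)c(Cl)cc2Cl)sc2c1CCOC2)c1ccc(C(=O)O)cc1`, gives 2.5 nM in a functional assay on CHO/Galpha16 cells for antagonist activity at prostaglandin E2 receptor EP4 subtype (Homo sapiens), read by calcium flux, with a stated time of 15 min (a higher number here means a weaker inhibitor, a lower number a stronger inhibitor), and is the lowest of the three numbers measured so far. Compound 1, `COc1cccc(C#Cc2sc3c(c2C(=O)N[C@@H](C)c2ccc(C(=O)O)cc2)CCOC3)c1`, gives 12.4 nM and compound 3, `C[C@H](NC(=O)c1c(C#Cc2ccc(=O)[nH]c2)sc2c1CCOC2)c1ccc(C(=O)O)cc1`, gives 642 nM. Compound 4, `C[C@H](NC(=O)c1c(Cc2ccc(C(C)(C)C)cc2)sc2c1CCOC2)c1ccc(C(=O)O)cc1`, carries 4-(tert-butyl)phenyl in place of 2,4-dichloro-5-fluorophenyl on a saturated chain carbon bound to an aromatic carbon. Among the measured compounds shown here, no measured step makes exactly this swap, but two steps change the same outer ring: a 5.0-fold lower number from compound 1 to compound 2 (0.70 log units; beyond the scatter) and a 260-fold higher number from compound 2 to compound 3 (2.41 log units; beyond the scatter). The first shows that a ring of carbon only with different substituents shifts the number modestly; the second shows a ring with one hetero atom costs far more. Compound 4 keeps a carbon-only ring, so a modest step is expected, a 3.2-fold higher number from compound 2 to compound 4 (0.51 log units; beyond the scatter), and compound 4 is expected to give about 8 nM, between 2 nM and 40 nM.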

Compound 4, half-maximal inhibitory concentration: 9.5 nM
Compound 4: the middle estimate sits 1.2-fold (0.07 log units) below what was measured, within the range that was stated.
By their numbers in this assay, from the lowest: compound 2; then compounds 4 and 1 (each within the scatter of the next); then compound 3.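

In this assay, 4-(tert-butyl)phenyl on a saturated chain carbon bound to an aromatic carbon costs only a 3.8-fold higher number from compound 2 to compound 4 (0.58 log units; beyond the scatter), so a low number here does not depend on the chlorine and fluorine atoms of 2,4-dichloro-5-fluorophenyl. The 4-(tert-butyl)benzyl group is within the scatter of 2-(3-methoxyphenyl)ethynyl, at a 1.3-fold lower number from compound 1 to compound 4 (0.12 log units; within the scatter), and it differs far more from the group in compound 3, at a 68-fold lower number from compound 3 to compound 4 (1.83 log units; beyond the scatter). No available evidence explains these differences. From the compounds shown here alone, how a single chlorine or an amine on this ring would change the number remains open.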